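A fused ring exchanged on the side chain

A few compounds are considered here, and "the series" means these few. Any claim that something is new, unique, unknown or untested is made for them only; others in the source may bear on it.

- compound 1 `COC(=O)c1c(C)cc(OC(=O)c2c(C)cc(O)c(/C=N/NC(=O)Cc3ccccc3)c2O)c(C)c1O` with > 100000 nM (a limit)
- compound 2 `COC(=O)c1c(C)cc(OC(=O)c2c(C)cc(O)c(/C=N/NC(=O)COc3ccc4ccccc4c3)c2O)c(C)c1O` with 52700 nM

Going by the values given here, in an ADME assay on HEK293 cells (Homo sapiens) for cytotoxicity (on this read-out higher numbers stand for weaker inhibition and lower numbers for stronger inhibition), compound 2 gives 52700 nM as the only actual number so far. The reading for compound 1 is a limit, (the limit of > 100000 nM in this assay, at which 1 of the 2 values shown sits), and not a number.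

Compound 3 `COC(=O)c1c(C)cc(OC(=O)c2c(C)cc(O)c(/C=N/NC(=O)COc3cc4ccccc4o3)c2O)c(C)c1O` has not yet been measured. It carries 1-benzofuran-2-yl in place of naphthalen-2-yl on an oxygen on a saturated carbon.

Among the compounds with values here, only one measured step bears on this change, and it exchanged a different group on the same side chain: an at least 1.8-fold lower number from compound 1 to compound 2 (0.27 log units; that floor lies within the scatter). That step gives only a floor for its size, and it does not involve 1-benzofuran-2-yl. The data therefore offer no basis for predicting a shift in either direction, and no change beyond the scatter is expected. The expected step is a 1.0-fold higher number from compound 2 to compound 3 (0.02 log units; within the scatter) and it stays within that scatter.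

In this assay the estimated value for compound 3 is 55000 nM, with an expected range from 25000 nM to 100000 nM and some chance that only a limit is reported.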

Compound 3, half-maximal inhibitory concentration: 84400 nM
Compound 3: the middle estimate sits 1.5-fold (0.19 log units) below what was measured, and the stated range covers the measured number.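

In this assay, the exchange of naphthalen-2-yl for 1-benzofuran-2-yl on the oxygen gives a 1.6-fold higher number from compound 2 to compound 3 (0.20 log units; within the scatter), so a five-membered aromatic ring with 1 hetero atom can replace one of the six-membered aromatic rings of carbon only at this position without a shift that can be told from the scatter. Set against the phenyl side chain, the new group gives an at least 1.1-fold lower number from compound 1 to compound 3 (0.07 log units; that floor lies within the scatter), which adds no step of readable size to the one already seen for naphthalen-2-yl. The reading for compound 1 remains a limit, and it allows only a floor for each step that starts from it: the limit of > 100000 nM in this assay, at which 1 of the 3 values shown sits.

The compounds shown leave open whether the oxygen on the chain or the fused ring separates compound 2 and compound 3 from compound 1, since the two enter together in both steps. Going by these compounds, it also stays open whether a plain phenoxy group on the same chain carbon, or an amine or a carboxylic acid on the fused ring, would give a step beyond the scatter.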